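The compounds below may be only part of what the source reports. "The series", "measured", "known", "first", "only" and "open" are said of these compounds alone.

Two compounds share one core and differ only in the group carried on the pendant ring. Compound 1 `CS(=O)(=O)Nc1ccc([N+](=O)[O-])cc1OCc1ccc([N+](=O)[O-])cc1` bears a nitro group there, and in an assay on SK-BR-3 cells for inhibition of Aromatase (Homo sapiens) (on this read-out lower numbers stand for stronger inhibition and higher numbers for weaker inhibition), compound 1 gives 400 nM. Among the measured compounds shown here, compound 2 `CS(=O)(=O)Nc1ccc([N+](=O)[O-])cc1OCc1ccc(Br)cc1` carries bromo instead, and in this assay compound 2 gives 5850 nM; that is the highest of the two numbers known, and the single measured step, a 15-fold higher number from compound 1 to compound 2 (1.17 log units; beyond the scatter), shows how much that one swap changed the read-out. Compound 3 `CS(=O)(=O)Nc1ccc([N+](=O)[O-])cc1OCc1ccc(-c2ccccc2)cc1` takes the next step from compound 2: phenyl in place of bromo on an aromatic carbon, placed para to a large group. For the measured compounds named here, no measured pair shows what a phenyl does at this spot, so the one known step, from nitro to bromo, offers only a loose guide and does not fix a direction. The number for compound 3 is therefore estimated close to that of compound 2, as a step of a 1.5-fold lower number from compound 2 to compound 3 (0.17 log units; within the scatter), with an expected value near 4000 nM and a wide range from 800 nM to 20000 nM.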

Compound 3, half-maximal inhibitory concentration: 850 nM
Compound 3: the middle estimate sits 4.7-fold (0.67 log units) above what was measured; the range from low to high includes it.
By their numbers in this assay, from the lowest: compound 1; then compound 3; then compound 2.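

In this assay the spot on the pendant ring accepts far more than a single atom: phenyl, with six heavy atoms and a whole aromatic ring, replaces the one bromine and gives a 6.9-fold lower number from compound 2 to compound 3 (0.84 log units; beyond the scatter), so a bigger group does not by itself mean a higher number here. Nitro still holds the lowest number of the three, yet the remaining gap is a 2.1-fold higher number from compound 1 to compound 3 (0.33 log units; beyond the scatter), which means phenyl wins back most of what the bromo swap lost. Nothing available explains why these groups rank in this order.

Three groups at one spot are too few to give a trend. From the compounds shown here alone, whether an amine, a carboxylic acid or a longer carbon chain at this spot would fall below compound 1 or above compound 2 remains open.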